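This account rests on a few compounds, and the source may have more. Where it says the series, first, only, none or still open, it means among the compounds named here.

Measured so far:
- compound 1 `Cc1cc(O)cc(S(=O)(=O)c2cccc(N)c2C#N)c1`: 167000 nM
- compound 2 `CCOc1cc(C)cc(S(=O)(=O)c2cccc(N)c2C#N)c1`: 9000 nM
- compound 3 `CCCOc1cc(C)cc(S(=O)(=O)c2cccc(N)c2C#N)c1`: 11000 nM

In a functional assay on MT4 cells (Homo sapiens) for cytotoxicity (a lower number here means a stronger inhibitor, a higher number a weaker inhibitor), compound 3 gives 11000 nM, level within the scatter with compound 2 and far under compound 1. Compound 4 `CCCCOc1cc(C)cc(S(=O)(=O)c2cccc(N)c2C#N)c1` lengthens propyl to butyl: methyl in place of hydrogen on a saturated chain carbon, three bonds along the chain from an oxygen on an aromatic ring.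

Among the measured compounds shown here, the closest precedent is the previous chain extension, a 1.2-fold higher number from compound 2 to compound 3 (0.09 log units; within the scatter). The large steps, a 19-fold lower number from compound 1 to compound 2 (1.27 log units; beyond the scatter) and a 15-fold lower number from compound 1 to compound 3 (1.18 log units; beyond the scatter), come from replacing the hydrogen on the oxygen, a change compound 3 already carries. No step beyond the scatter is therefore expected in this assay. The expected step is a 1.1-fold lower number from compound 3 to compound 4 (0.04 log units; within the scatter). Compound 4 is estimated at 10000 nM, with an expected range of 5000 nM to 20000 nM.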

Compound 4, half-maximal inhibitory concentration: > 2000 nM
Compound 4: only a limit was reported; the forecaster's own chance of this, stated with the estimate: 3%; the middle value lies beyond the limit too.
By their numbers in this assay, from the lowest: compounds 2 and 3 (each within the scatter of the next); then compound 1.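

In this assay compound 4 gives > 2000 nM, a limit and not a number, so its steps from compound 1, compound 2 and compound 3 cannot be read. The compounds shown leave open whether butyl stays level with ethyl and propyl.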